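Chloro in Place of Hydrogen: From Compound 3 to Compound 4

The source may report more compounds than this note shows. Statements on the series, on what has been measured and on what is new or still open speak of the compounds shown alone.

In a functional assay on cells (Cancer cell lines, Homo sapiens) for cytotoxicity, read by sulforhodamine B assay, with a stated time of 48 h (on this read-out higher numbers stand for weaker inhibition of growth and lower numbers for stronger inhibition of growth), compound 3 `Oc1ccc(O)c(-c2cc(-c3ccccc3)nn2-c2ccccc2)c1` gives 26900 nM, the highest of the three numbers, though within the scatter of both compound 2 `COc1ccc(OC)c(-c2cc(-c3ccc(Cl)cc3)nn2-c2ccc(S(=O)(=O)NC(C)=O)cc2)c1` at 17700 nM and compound 1 `COc1ccc(OC)c(-c2cc(-c3ccccc3)nn2-c2ccc(S(=O)(=O)NC(C)=O)cc2)c1` at 15300 nM. Compound 4 `Oc1ccc(O)c(-c2cc(-c3ccc(Cl)cc3)nn2-c2ccccc2)c1` differs from compound 3 by chloro in place of hydrogen on an aromatic carbon, placed on an aromatic carbon of a six-membered aromatic ring of carbon only, para to a large group. Among the compounds with values here, the one measured step of the same kind, a 1.2-fold higher number from compound 1 to compound 2 (0.06 log units; within the scatter), stayed within the scatter on the other pair, and no other step bears on it. The step of a 1.1-fold higher number from compound 3 to compound 4 (0.05 log units; within the scatter) is therefore expected to stay within the scatter, with no direction beyond it. Compound 4 is thus estimated at 30000 nM, with a range from 15000 nM to 60000 nM in this assay.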

Compound 4, concentration for 50% growth inhibition: 6850 nM
The estimate for compound 4 lay 4.4-fold (0.64 log units) above the measured number, and the stated range ends above it.
By their numbers in this assay, from the lowest: compound 4; then compounds 1, 2 and 3 (each within the scatter of the next).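

Chloro in place of hydrogen, on an aromatic carbon para to a large group, now gives a change beyond the scatter in this assay: a 3.9-fold lower number from compound 3 to compound 4 (0.59 log units; beyond the scatter). The earlier pair had shown no such change, so the effect of phenyl to 4-chlorophenyl is not the same on every core: the same change on two cores in this assay, a 1.2-fold higher number (0.06 log units; within the scatter) from compound 1 to compound 2 and a 3.9-fold lower number (0.59 log units; beyond the scatter) from compound 3 to compound 4, 4.5-fold (0.66 log units) apart, beyond the scatter of two such steps

The compounds shown leave open whether a bromo, a methoxy or an amine in the same place would act as chloro does on the core of compound 3. On these data alone, the two cores differ in more than one place, and which of those differences separates the two steps remains open.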